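The compounds below may be only part of what the source reports. "The series", "measured", "known", "first", "only" and "open" are said of these compounds alone.

Compound 1 `COc1cc(C(=O)C2Sc3nnc(-c4cc(OC)c(OC)c(OC)c4)n3NC2c2ccco2)cc(OC)c1OC` and compound 2 `COc1cc(-c2nnc3n2NC(c2ccco2)C(C(=O)c2ccc(F)cc2)S3)cc(OC)c1OC` share the same core and differ only in the aryl group on the carbonyl carbon. In a functional assay on HepG2 cells (Homo sapiens) for cytotoxicity, read by MTT assay, with a stated time of 48 h (a higher number here means a weaker inhibitor, a lower number a stronger inhibitor), compound 1 gives > 100000 nM, which is a limit of the assay and not a number. In this assay compound 2 likewise gives > 100000 nM, again a limit. Among the compounds with values here, the one measured step, a step that the two limits leave unreadable from compound 1 to compound 2, therefore shows nothing about the size or direction of exchanging the aryl on the carbonyl carbon; the limit of > 100000 nM in this assay, at which 2 of the 2 values shown sit, is all that the two compounds offer.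

Compound 3 `COc1cc(-c2nnc3n2NC(c2ccco2)C(C(=O)c2cccc4ccccc24)S3)cc(OC)c1OC` carries the next variation at the same place: naphthalen-1-yl in place of 4-fluorophenyl on a carbonyl carbon. Within the data shown here, no measured step of readable size bears on this change, and both compounds measured so far sit at the limit of this assay. Compound 3 is therefore expected to sit at or near that limit, with the step that the limit leaves unreadable from compound 2 to compound 3 not expected to exceed the scatter. The estimate for compound 3 in this assay is 150000 nM, within 30000 nM to 600000 nM.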

Compound 3, half-maximal inhibitory concentration: 33900 nM
For compound 3 the middle estimate is 4.4-fold (0.65 log units) above the measured one, and the stated range covers the measured number.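

In this assay the aryl group on the carbonyl carbon turns out to matter, which the first two compounds could not show: an at least 2.9-fold lower number from compound 2 to compound 3 (0.46 log units; beyond the scatter) with naphthalen-1-yl in place of 4-fluorophenyl, and an at least 2.9-fold lower number from compound 1 to compound 3 (0.46 log units; beyond the scatter) with naphthalen-1-yl in place of 3,4,5-trimethoxyphenyl. Both steps start from a limit of the assay, so they fix only a minimum size, and the step between compound 1 and compound 2 cannot be read. Compound 3, with two six-membered aromatic rings in the entering group, is the only one of the three with a measured number, and the others stay at the limit: the limit of > 100000 nM in this assay, at which 2 of the 3 values shown sit.

Going by these compounds, it remains open whether the gain belongs to the naphthalen-1-yl group specifically or would also appear with naphthalen-2-yl. On these data alone, it is equally open how far an amine or a carboxylic acid on that aryl group would move the value.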